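A few compounds are considered here, and "the series" means these few. Any claim that something is new, unique, unknown or untested is made for them only; others in the source may bear on it.

In a functional assay on corpus cavernosum (Rattus norvegicus) for activation (on this read-out lower numbers stand for an effect already at smaller amounts and higher numbers for an effect only at larger amounts of compound), compound 1 `O=c1[nH]c(-c2ccccc2O)nc2c1cnn2-c1ccccc1` gives 500 nM, compound 2 `CC(C)Oc1ccccc1-c1nc2c(cnn2-c2ccccc2)c(=O)[nH]1` gives 500 nM and compound 3 `O=c1[nH]c(-c2ccccc2O)nc2c1cnn2-c1ccc(Br)cc1` gives 338 nM. Compound 3 thus lies within the scatter of both other compounds. Compound 4 `CCCCOc1ccccc1-c1nc2c(cnn2-c2ccc(Br)cc2)c(=O)[nH]1` differs from compound 3 by butyl in place of hydrogen on an oxygen on an aromatic ring. The closest measured precedent is no change at the digits printed from compound 1 to compound 2 (within the scatter), where isopropyl replaces that hydrogen. The bromo exchange already present in compound 3 shows a 1.5-fold lower number from compound 1 to compound 3 (0.17 log units; within the scatter). Among the compounds with values here, no measured compound carries butyl, so that chain remains untested. The expected step is a 1.0-fold higher number from compound 3 to compound 4 (0.00 log units; within the scatter), none beyond the scatter. Compound 4 is estimated at 340 nM, within a range of 150 nM to 750 nM.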

Compound 4, half-maximal effective concentration: 4.89 nM
Compound 4: the middle estimate sits 70-fold (1.84 log units) above what was measured; measured number outside the range, below it.
By their numbers in this assay, from the lowest: compound 4; then compounds 3, 1 and 2 (each within the scatter of the next).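

On the oxygen of the hydroxy group, the change from hydroxy to butoxy is not silent in this assay: butyl in place of hydrogen gives a 69-fold lower number from compound 3 to compound 4 (1.84 log units; beyond the scatter), whereas isopropyl gave no change at the digits printed from compound 1 to compound 2 (within the scatter) on the compound without bromo. The oxygen therefore tolerates substitution, and at least one group placed there brings a large change in this read-out. No measurement offered here explains why the butyl step is so large. The compounds shown leave open whether butyl would do the same without the bromo, or whether the isopropyl would with it. They also leave open how a longer chain such as hexyl, or a chain carrying an amine, would behave on this oxygen.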